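What replacing phenyl may do to compound 3

A few compounds are considered here, and "the series" means these few. Any claim that something is new, unique, unknown or untested is made for them only; others in the source may bear on it.

In a physicochemical assay for solubility, read by spectrophotometry, in phosphate buffer, measured as kinetic solubility, with a stated time of 18 h, at pH 7.4 (on this read-out higher numbers stand for higher solubility and lower numbers for lower solubility), compound 1 (`O=C(O)COc1cc(Cl)c(C(=O)Nc2cccc(-c3nc4ccccc4s3)c2)cc1[N+](=O)[O-]`) gives 6700 nM. With hydrogen in place of carboxymethoxy on an aromatic carbon, compound 2 (`O=C(Nc1cccc(-c2nc3ccccc3s2)c1)c1cc([N+](=O)[O-])ccc1Cl`) gives 580 nM, and this large move is a 12-fold lower number from compound 1 to compound 2 (1.06 log units; beyond the scatter). With phenyl in place of 1,3-benzothiazol-2-yl, compound 3 (`O=C(Nc1cccc(-c2ccccc2)c1)c1cc([N+](=O)[O-])ccc1Cl`) gives 410 nM, a move of a 1.4-fold lower number from compound 2 to compound 3 (0.15 log units; within the scatter) that stays within the normal scatter of repeat measurements. Compound 3 therefore sits level with compound 2, and the values of both lie far under that of compound 1.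

The next change gives compound 4 (`O=C(Nc1cccc(-c2nc3ccccc3[nH]2)c1)c1cc([N+](=O)[O-])ccc1Cl`), with 1H-benzimidazol-2-yl in place of phenyl on an aromatic carbon. The closest guide is the earlier swap at this same place, which gave a 1.4-fold lower number from compound 2 to compound 3 (0.15 log units; within the scatter) and so no clear shift. The large step, a 12-fold lower number from compound 1 to compound 2 (1.06 log units; beyond the scatter), concerns carboxymethoxy, a group that neither compound 3 nor compound 4 carries, so it offers little guidance here. Going by the values given here, no measured compound carries 1H-benzimidazol-2-yl, which leaves real uncertainty. In this assay, no change beyond the scatter is expected, with an estimated 1.2-fold higher number from compound 3 to compound 4 (0.09 log units; within the scatter). For compound 4 the estimated value is 500 nM, with an expected range from 200 nM to 1300 nM.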

Compound 4, solubility: 1400 nM
Estimate against measurement, compound 4: 2.8-fold (0.45 log units) below; the measured number lies above the stated range.
By their numbers in this assay, from the lowest: compounds 3 and 2 (each within the scatter of the next); then compound 4; then compound 1.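

In this assay, this place on an aromatic carbon, meta to a large group, now proves able to move the number beyond the scatter (a 3.4-fold higher number from compound 3 to compound 4 (0.53 log units; beyond the scatter)), whereas the earlier swap here gave no clear shift (a 1.4-fold lower number from compound 2 to compound 3 (0.15 log units; within the scatter)). The outcome also depends on which group sits here, since 1H-benzimidazol-2-yl and 1,3-benzothiazol-2-yl, though both differ from phenyl, do not behave alike (a 2.4-fold higher number from compound 2 to compound 4 (0.38 log units; beyond the scatter)). Phenyl counts 0 hydrogen-bond donors and 0 hydrogen-bond acceptors while 1H-benzimidazol-2-yl counts 1 of each, but no measurement here ties either count, or anything else about these groups, to the rise.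

On these data alone, it remains open whether the ring hydrogen of 1H-benzimidazol-2-yl matters, which a methyl group on that ring nitrogen could help to show, and whether a smaller group at this place, such as an amine, could shift the number in the same way. Going by these compounds alone, it is also open whether the step seen with 1H-benzimidazol-2-yl would hold on a core that also carries carboxymethoxy, the group involved in the largest step so far.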